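The source may report more compounds than this note shows. Statements on the series, on what has been measured and on what is new or still open speak of the compounds shown alone.

Of the compounds shown here, three built on one shared core have been measured in an ADME assay on the whole organism (strain Sprague-Dawley) for pharmacokinetics, with Rattus norvegicus as the target, at a dose of 2.5 mg/kg; on this read-out lower numbers stand for narrower distribution and higher numbers for wider distribution into tissues. Compound 1 `CC(C)(CC(F)(F)F)NC(=O)N1Cc2nc(N)nc(-c3c(Cl)cc(Cl)cc3OCCn3cccn3)c2C1` gives 2 L/kg. Compound 3 `CC(C)(CC(F)(F)F)NC(=O)N1Cc2nc(N)nc(-c3c(Cl)cc(Cl)cc3OCCn3cc(F)cn3)c2C1` gives 13 L/kg. Compound 2 `CC(C)(NC(=O)N1Cc2nc(N)nc(-c3c(Cl)cc(Cl)cc3OCCn3cc(F)cn3)c2C1)C12CC(C1)C2` gives 11 L/kg. Compound 1 differs from compound 3 by hydrogen in place of fluoro on an aromatic carbon, and this change made a 6.5-fold lower number from compound 3 to compound 1 (0.81 log units; beyond the scatter). The cores of compound 2 and compound 3 differ by a group of 5 heavy atoms (5 carbon; 2 four-membered non-aromatic rings of carbon only) in place of a group of 5 heavy atoms (2 carbon, 3 fluorine; no ring), on a saturated chain carbon bound to an amide-type nitrogen and two saturated chain carbons, which made a 1.2-fold higher number from compound 2 to compound 3 (0.07 log units; within the scatter). Compound 4 `CC(C)(NC(=O)N1Cc2nc(N)nc(-c3c(Cl)cc(Cl)cc3OCCn3cccn3)c2C1)C12CC(C1)C2` has not yet been measured; it differs from compound 2 by hydrogen in place of fluoro on an aromatic carbon, the same change as that between compound 3 and compound 1, at the same place. Because the earlier instance of this change gave a 6.5-fold lower number from compound 3 to compound 1 (0.81 log units; beyond the scatter), the new step is expected to be of similar size, namely a 4.4-fold lower number from compound 2 to compound 4 (0.64 log units; beyond the scatter). Compound 4 is therefore estimated at 2.5 L/kg, with a likely range from 1 L/kg to 6 L/kg.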

Compound 4, volume of distribution at steady state: 1.8 L/kg
Compound 4: the middle estimate sits 1.4-fold (0.14 log units) above what was measured; low and high end bracket the measured number.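

In this assay, hydrogen in place of fluoro gave a 6.1-fold lower number from compound 2 to compound 4 (0.79 log units; beyond the scatter), so the change carried over between the two cores shown: the same change on two cores in this assay, a 6.5-fold lower number (0.81 log units; beyond the scatter) from compound 3 to compound 1 and a 6.1-fold lower number (0.79 log units; beyond the scatter) from compound 2 to compound 4, 1.1-fold (0.03 log units) apart, within the scatter of two such steps The exchange of the two groups on the saturated chain carbon gave a 1.1-fold lower number from compound 1 to compound 4 (0.05 log units; within the scatter), and it likewise made no readable difference with either fluoro or hydrogen on the aromatic ring: the same change on two cores in this assay, a 1.2-fold higher number (0.07 log units; within the scatter) from compound 2 to compound 3 and a 1.1-fold higher number (0.05 log units; within the scatter) from compound 4 to compound 1, 1.1-fold (0.03 log units) apart, within the scatter of two such steps This rests on just two cores that differ in one group, so it does not show that the step would hold on a core changed elsewhere, nor does it explain the step. The compounds shown leave open whether a chloro or a methyl group on that aromatic carbon would give a step of similar size.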